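Ring nitrogen substituents: the step to compound 4

The compounds below may be only part of what the source reports. "The series", "measured", "known", "first", "only" and "open" are said of these compounds alone.

Measured in an in vitro ADME assay on microsomes from liver (Mus musculus) for pharmacokinetics, read by LC-MS, with a stated time of 10 min, tested at 1 uM; a lower number here means slower removal, a higher number faster removal of the compound:
- compound 1 `CCN1C[C@H](C(=O)Nc2ccc(Cl)cc2)[C@@H](c2ccc(/C=C/C(=O)Nc3ccccc3N)cc2)C1`: 35 mL/min/kg
- compound 2 `CC(C)(C)N1C[C@H](C(=O)Nc2ccc(Cl)cc2)[C@@H](c2ccc(/C=C/C(=O)Nc3ccccc3N)cc2)C1`: 20 mL/min/kg
- compound 3 `CC(C)(CO)N1C[C@H](C(=O)Nc2ccc(Cl)cc2)[C@@H](c2ccc(/C=C/C(=O)Nc3ccccc3N)cc2)C1`: 40 mL/min/kg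

In this assay, compound 3 stands at 40 mL/min/kg, within the scatter of both other compounds. The next structure is compound 4 `CCN(CC)C(=O)N1C[C@H](C(=O)Nc2ccc(Cl)cc2)[C@@H](c2ccc(/C=C/C(=O)Nc3ccccc3N)cc2)C1`, with the change diethylcarbamoyl in place of 1-(hydroxymethyl)-1-methylethyl on an amine nitrogen in a ring.

All measured steps concern this same ring nitrogen: a 1.8-fold lower number from compound 1 to compound 2 (0.24 log units; within the scatter), a 1.1-fold higher number from compound 1 to compound 3 (0.06 log units; within the scatter) and a 2.0-fold higher number from compound 2 to compound 3 (0.30 log units; within the scatter). Each lies within the scatter, including the largest of them. None of them brings a diethylcarbamoyl group onto the nitrogen, so they guide this change only loosely, and the range has to stay wide. No step beyond the scatter is expected in this assay, and the data support no firm direction. The expected step is a 1.1-fold lower number from compound 3 to compound 4 (0.06 log units; within the scatter). The estimate for compound 4 is 35 mL/min/kg, with an expected range of 15 mL/min/kg to 80 mL/min/kg.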

Compound 4, clearance: 83 mL/min/kg
Estimate against measurement, compound 4: 2.4-fold (0.38 log units) below; the measured number lies above the stated range.
By their numbers in this assay, from the lowest: compounds 2, 1 and 3 (each within the scatter of the next); then compound 4.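

In this assay, among these compounds, diethylcarbamoyl on the amine nitrogen in a ring is the first group at this position to give steps beyond the scatter (a 2.1-fold higher number from compound 3 to compound 4 (0.32 log units; beyond the scatter); a 2.4-fold higher number from compound 1 to compound 4 (0.38 log units; beyond the scatter); a 4.2-fold higher number from compound 2 to compound 4 (0.62 log units; beyond the scatter)). Ethyl, tert-butyl and 1-(hydroxymethyl)-1-methylethyl remain within the scatter of one another, while compound 4 stands apart from all three with the highest number of the four, meaning the fastest removal. Nothing at hand explains this separation.

The compounds shown leave open whether the higher number goes with the carbonyl on the nitrogen or with the two ethyl groups. An acetyl or a dimethylcarbamoyl group at this position would help separate the two, and a sulfonyl group would show whether the step extends beyond carbonyl-linked substituents.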